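The compounds below may be only part of what the source reports. "The series", "measured", "known", "first", "only" and "open" are said of these compounds alone.

Compound 2, with the structure `Cc1ccc(S(=O)(=O)N[C@@H](CC(=O)NC(C)(C)C)C(=O)NCCNC(=O)c2cccc(F)c2)cc1`, stands on a limit rather than on a number in an ADME assay on Karpas-1106P cells (Homo sapiens) for cytotoxicity; a lower number here means that less compound is needed, a higher number that more compound is needed for the effect. In this assay compound 2 gives > 11100 nM, which is a limit of the assay and not a measured value. Among the measured compounds shown here, compound 1, with the structure `Cc1ccc(S(=O)(=O)N[C@@H](CC(=O)NC(C)(C)C)C(=O)NCCNC(=O)Nc2ccccc2)cc1`, is the only other compound measured here; in this assay compound 1 gives > 11100 nM, likewise a limit. The step that the two limits leave unreadable from compound 1 to compound 2 therefore cannot be read, because both values sit at the limit of > 11100 nM in this assay, at which 2 of the 2 values shown sit, so nothing is known about how large a change at this position can make.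

Compound 3, with the structure `Cc1ccc(S(=O)(=O)N[C@@H](CC(=O)NC(C)(C)C)C(=O)NCCNC(=O)c2cc(C)ccn2)cc1`, differs from compound 2 in one place: 4-methylpyridin-2-yl in place of 3-fluorophenyl on a carbonyl carbon.

For the measured compounds named here, no measured step bears on this change, since the single step on record is unreadable. Going by the values given here, the only guide is that both measured compounds sit at the limit, so the expectation is that compound 3 stays there as well, with the step that the limit leaves unreadable from compound 2 to compound 3 expected to be none beyond the scatter. On that basis compound 3 is estimated to give 20000 nM in this assay, within a range from 8000 nM to 100000 nM, most likely reported again only as a limit.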

Compound 3, half-maximal effective concentration: > 11100 nM
Compound 3 gave a limit, no number (the forecaster's own chance of this, stated with the estimate: 85%); the middle value is on the limit's open side.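

In this assay compound 3 gives > 11100 nM, which is a limit and not a number. No step from compound 1 or compound 2 to compound 3 can be read, because all three compounds share one limit: the limit of > 11100 nM in this assay, at which 3 of the 3 values shown sit.

The compounds shown leave open whether any group on this carbonyl carbon can bring a measurable value in this cytotoxicity read-out, and how large such a change could be.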